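The source may hold more compounds than are shown below. What is called first, only, known or untested is meant among the compounds shown, and "the series" means these compounds.

Of the compounds shown here, three have so far been measured in a functional assay on CCRF-CEM cells (Homo sapiens); a lower number here means that less compound is tolerated, a higher number that more compound is tolerated. Compound 1 `CC(=O)NC1=CS(=O)(=O)O[C@@]12[C@@H](CO[Si](C)(C)C(C)(C)C)O[C@@H](n1cc(C)c(=O)n(C)c1=O)[C@@H]2O[Si](C)(C)C(C)(C)C` gives 25700 nM in this assay. Compound 2 `Cc1cn([C@@H]2O[C@@H]3COC(=O)[C@]3(OS(C)(=O)=O)[C@H]2O)c(=O)[nH]c1=O` gives 160000 nM, and compound 3 `Cc1cn([C@@H]2O[C@@H]3COC4(O)CS(=O)(=O)O[C@@]34[C@H]2O[Si](C)(C)C(C)(C)C)c(=O)[nH]c1=O` gives 100000 nM. Compound 1 therefore stands at the lowest number of the three, and its gaps to compound 3 and to compound 2 both lie beyond the usual scatter of this assay. Compound 4 `Cc1cn([C@@H]2O[C@H](CO[Si](C)(C)C(C)(C)C)[C@@]3(OS(=O)(=O)C=C3NC(=O)c3ccccc3)[C@H]2O[Si](C)(C)C(C)(C)C)c(=O)n(C)c1=O` has not yet been measured. It differs from compound 1 in one place: phenyl in place of methyl on a carbonyl carbon. Going by the values given here, no measured pair shows what such a change does in this assay, so no direction can be read from the data. The step that this estimate means, a 1.2-fold lower number from compound 1 to compound 4 (0.07 log units; within the scatter), is expected to stay within the scatter. Compound 4 is thus estimated at 22000 nM, with a range from 7000 nM to 70000 nM.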

Compound 4, half-maximal cytotoxic concentration: 4910 nM
Beside the measured number, compound 4's estimate is 4.5-fold (0.65 log units) above it; measured number outside the range, below it.
By their numbers in this assay, from the lowest: compound 4; then compound 1; then compounds 3 and 2 (each within the scatter of the next).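

Going by these compounds alone, this is the first measured pair to show that this carbonyl carbon responds to a change: in this assay, phenyl in place of methyl gives a 5.2-fold lower number from compound 1 to compound 4 (0.72 log units; beyond the scatter). Turning acetamido into benzamido therefore means that less compound is tolerated, with the rest of compound 1 unchanged. Nothing available explains this shift.

A single pair cannot show whether the aromatic ring itself matters or whether any larger group would do the same. Cyclohexyl or a longer chain such as butyl on this carbonyl carbon would help separate those two readings.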